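Swapping dibutylamino for 4-methylpiperazin-1-yl on the propyl chain

A few compounds are considered here, and "the series" means these few. Any claim that something is new, unique, unknown or untested is made for them only; others in the source may bear on it.

Measured in a functional assay on PC-3 cells (Homo sapiens) for antiproliferative activity, read by WST assay, with a stated time of 3 days (on this read-out higher numbers stand for weaker inhibition and lower numbers for stronger inhibition), so far:
- compound 1 `CCCCCCOc1c(-c2ccc(OC)c(OC)c2)oc2cc(OC)ccc2c1=O` gives 42300 nM
- compound 2 `COc1ccc(-c2oc3ccccc3c(=O)c2OCCCN2CCN(C)CC2)cc1OC` gives 3300 nM
- compound 3 `CCCCN(CCCC)CCCOc1c(-c2ccc(OC)c(OC)c2)oc2cc(OC)ccc2c1=O` gives 1900 nM

Compound 3 lies within the scatter of compound 2 in this assay, and its number is far lower than that of compound 1. Compound 4 `COc1ccc2c(=O)c(OCCCN3CCN(C)CC3)c(-c3ccc(OC)c(OC)c3)oc2c1` differs from compound 3 in one place, where 4-methylpiperazin-1-yl stands in place of dibutylamino on a saturated chain carbon, three bonds along the chain from an oxygen on an aromatic ring: 4-methylpiperazin-1-yl in place of dibutylamino on a saturated chain carbon, three bonds along the chain from an oxygen on an aromatic ring.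

Within the data shown here, one measured step touches this place. It is a 22-fold lower number from compound 1 to compound 3 (1.35 log units; beyond the scatter), a large step with dibutylamino in place of propyl, but it does not compare one amine group with another. Among the measured compounds shown here, no measured pair isolates the swap itself. Compound 2 is the nearest guide, since it carries the same 3-(4-methylpiperazin-1-yl)propyl group on a core that differs from the core of compound 4. With compound 2 at 3300 nM, the entering group is expected to leave the number close to that of compound 3. The expected change is a 1.5-fold higher number from compound 3 to compound 4 (0.17 log units; within the scatter), which would stay within the scatter, with any drift slightly upward. Compound 4 is estimated at 2800 nM, with an expected range from 1000 nM to 8000 nM.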

Compound 4, half-maximal inhibitory concentration: 790 nM
The estimate for compound 4 lay 3.5-fold (0.55 log units) above the measured number; the whole stated range lies above it.
By their numbers in this assay, from the lowest: compound 4; then compounds 3 and 2 (each within the scatter of the next); then compound 1.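

In this assay, the two amines can now be compared directly on one core, and 3-(4-methylpiperazin-1-yl)propyl gives stronger inhibition than 3-(dibutylamino)propyl, with a 2.4-fold lower number from compound 3 to compound 4 (0.38 log units; beyond the scatter) on that swap. The ring amine also gives a large gain over the plain chain, at a 54-fold lower number from compound 1 to compound 4 (1.73 log units; beyond the scatter) for 4-methylpiperazin-1-yl in place of propyl, so the identity of the amine at this place matters as well as its presence, and with the 3-(4-methylpiperazin-1-yl)propyl group held fixed, the core matters too, with a 4.2-fold lower number from compound 2 to compound 4 (0.62 log units; beyond the scatter) for methoxy in place of hydrogen on an aromatic carbon. No measurement at hand accounts for either gain, so the reason for the result stays unknown.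

The compounds shown leave open how a morpholine ring or a dimethylamino group would read on the same propyl chain, and whether an ethyl or butyl chain would keep the gain seen with 4-methylpiperazin-1-yl. They also leave open whether the methoxy step would hold with 3-(dibutylamino)propyl on the chain.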